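The compounds below may be only part of what the source reports. "The series", "measured", "known", "first", "only" and "open" are said of these compounds alone.

Compound 1 `COc1ccc(/C=N/NC(=O)Nc2ccc(Oc3ccnc4cc(OCCCN5CCCCC5)c(OC)cc34)c(F)c2)cc1`, compound 2 `COc1cc2c(Oc3ccc(NC(=O)N/N=C/c4ccc(C(F)(F)F)cc4)cc3F)ccnc2cc1OCCCN1CCCCC1`, compound 3 `COc1cc2c(Oc3ccc(NC(=O)N/N=C/c4ccc(OC(F)(F)F)cc4)cc3F)ccnc2cc1OCCCN1CCCCC1` and compound 4 `COc1cc2c(Oc3ccc(NC(=O)N/N=C/c4cccs4)cc3F)ccnc2cc1OCCCN1CCCCC1` share one core and differ only in the aromatic group attached to the carbon that carries a double bond to nitrogen. In an ADME assay on PBL cells (Homo sapiens) for cytotoxicity, read by MTT assay, with a stated time of 72 h (on this read-out higher numbers stand for weaker inhibition and lower numbers for stronger inhibition), compound 1 gives 126000 nM. For compound 2 the outcome in this assay is "not determined" (no result reported). For compound 3 the outcome in this assay is likewise "not determined" (no result reported), so compound 3 stands on no number of its own. Compound 4 differs from compound 3 by thiophen-2-yl in place of 4-(trifluoromethoxy)phenyl on a carbon with a double bond to nitrogen. Within the data shown here, with no measured step available, the change from compound 3 to compound 4 is expected to move this assay by no more than the usual scatter, in either direction. Compound 4 is therefore estimated at 100000 nM, within a range from 30000 nM to 300000 nM.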

Compound 4, half-maximal inhibitory concentration: 68700 nM
For compound 4 the middle estimate is 1.5-fold (0.16 log units) above the measured one; the range from low to high includes it.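

Among these compounds, this is the first measured step at this position: in this assay, thiophen-2-yl in place of 4-methoxyphenyl on a carbon with a double bond to nitrogen gives a 1.8-fold lower number from compound 1 to compound 4 (0.26 log units; within the scatter). For this pair, then, a five-membered aromatic ring with a sulfur atom and a six-membered carbon-only ring give readings that stay within the scatter. Nothing available here offers an explanation for this result.

Steps involving compound 2 or compound 3 cannot be read. As far as these compounds go, whether an amine or a carboxylic acid on the aromatic ring would move this reading beyond the scatter remains open.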